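This account rests on a few compounds, and the source may have more. Where it says the series, first, only, none or still open, it means among the compounds named here.

Measured so far in a functional assay on MCF7 cells (Homo sapiens) for cytotoxicity, read by MTT assay, with a stated time of 96 h; a lower number here means a stronger inhibitor, a higher number a weaker inhibitor:
- compound 1 `COc1cc(C(=O)c2cn(-c3cccc(C)c3)cc2-c2ccc(N)cc2)cc(OC)c1OC` gives 18 nM
- compound 2 `COc1cc(C(=O)c2cn(-c3cccc(N)c3)cc2-c2ccccc2[N+](=O)[O-])cc(OC)c1OC` gives 14 nM

Within the data shown here, compound 2, at 14 nM, stands within the usual scatter of compound 1, the only other measured compound, so the two cannot be ranked. The next compound to be read is compound 3 `COc1cc(C(=O)c2cn(-c3cccc(N)c3)cc2-c2ccc(N)cc2)cc(OC)c1OC`, which carries 4-aminophenyl in place of 2-nitrophenyl on an aromatic carbon and keeps the 3-aminophenyl group of compound 2: 4-aminophenyl in place of 2-nitrophenyl on an aromatic carbon. Among the measured compounds shown here, no measured pair isolates this change. Compound 1 also carries 4-aminophenyl at that place and gives 18 nM, which gives no sign of a loss with that group. In this assay no step beyond the scatter is therefore expected, and the expected step is a 1.1-fold higher number from compound 2 to compound 3 (0.03 log units; within the scatter). For compound 3 the estimated value is 15 nM, with an expected range of 5 nM to 45 nM.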

Compound 3, half-maximal inhibitory concentration: 14 nM
Compound 3: the middle estimate sits 1.1-fold (0.03 log units) above what was measured; measured number inside the range.
By their numbers in this assay, from the lowest: compounds 2, 3 and 1 (each within the scatter of the next).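

In this assay the series now has its first pairs that differ in one place, and 4-aminophenyl in place of 2-nitrophenyl on an aromatic carbon gives no change at the digits printed from compound 2 to compound 3 (within the scatter), so these two groups cannot be told apart at this position while the 3-aminophenyl group is kept. Amino in place of methyl on an aromatic carbon gives a 1.3-fold lower number from compound 1 to compound 3 (0.11 log units; within the scatter), so with 4-aminophenyl in place that change cannot be read as a step either. No measurement available bears on why these groups read alike.

On these data alone, whether a carboxylic acid or a longer chain at this position would separate from these groups stays open. Also open, as far as these compounds go, is how methyl in place of amino reads alongside 2-nitrophenyl, and whether any step beyond the scatter can be found in this part of the series.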